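This account rests on a few compounds, and the source may have more. Where it says the series, first, only, none or still open, it means among the compounds named here.

Within the data shown here, compound 2 `CCc1cccc(CC)c1-n1nncc1CN1C(=O)C2(C(C#N)=C(N)Oc3c(N)cc4nc5ccccc5nc4c32)c2ccccc21` is the only compound in this set that gives a number rather than a limit: in a functional assay on HepG2 cells (Homo sapiens) for antiproliferative activity, read by MTT assay, with a stated time of 48 h (on this read-out higher numbers stand for weaker inhibition and lower numbers for stronger inhibition), compound 2 gives 16500 nM. Compound 1 `N#CC1=C(N)Oc2c(N)cc3nc4ccccc4nc3c2C12C(=O)N(Cc1cnnn1-c1cccc(Br)c1)c1ccccc12` carries a 3-bromophenyl on the same aromatic nitrogen, and in this assay compound 1 gives > 50000 nM, which is a limit of the assay and not a number. Among the measured compounds shown here, the one measured step, an at least 3.0-fold lower number from compound 1 to compound 2 (0.48 log units; beyond the scatter), is therefore known only as a lower bound, since it rests on (the limit of > 50000 nM in this assay, at which 1 of the 2 values shown sits).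

Compound 3 `Cc1ccc(Cl)cc1-n1nncc1CN1C(=O)C2(C(C#N)=C(N)Oc3c(N)cc4nc5ccccc5nc4c32)c2ccccc21` differs from compound 2 at the same position: 5-chloro-2-methylphenyl in place of 2,6-diethylphenyl on an aromatic nitrogen. The change keeps a disubstituted phenyl on the triazole nitrogen but removes one of the two ethyl groups and replaces the other with a methyl, while adding a chlorine. For the measured compounds named here, the only step that bears on this position, an at least 3.0-fold lower number from compound 1 to compound 2 (0.48 log units; beyond the scatter), shows that swapping the aryl group here can move the number by at least a modest amount in either direction. The account therefore expects compound 3 to land near compound 2 or somewhat higher, with a real chance of hitting the limit again; the expected step is a 1.5-fold higher number from compound 2 to compound 3 (0.18 log units; within the scatter), and the estimate for compound 3 in this assay is 25000 nM, within a range from 8000 nM to 60000 nM.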

Compound 3, half-maximal inhibitory concentration: 17300 nM
For compound 3 the middle estimate is 1.4-fold (0.16 log units) above the measured one; the measured number falls inside the stated range.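

In this assay, the step of a 1.0-fold higher number from compound 2 to compound 3 (0.02 log units; within the scatter) lies within the scatter, so this exchange on the aromatic nitrogen gives no measurable difference, although chlorine and methyl take the place of two ethyl groups on the phenyl ring. Among these compounds, the position therefore tolerates at least two different disubstituted phenyl groups with no separable effect on this read-out, which the single earlier step could not show. Among these three compounds, the two disubstituted phenyl groups give numbers and the 3-bromophenyl group of compound 1 gives a limit, and the second step away from that group, an at least 2.8-fold lower number from compound 1 to compound 3 (0.46 log units; beyond the scatter), is beyond the scatter but again known only as a lower bound: the limit of > 50000 nM in this assay, at which 1 of the 3 values shown sits.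

How far compound 1 really lies from the other two remains unknown, and with only three aryl groups shown, the pattern cannot be separated from the particular substituents they carry. Also open, on these data alone, is whether a phenyl ring bearing an amine or a carboxylic acid, or a longer alkyl chain in place of ethyl, would move the number beyond the scatter from those of compound 2 and compound 3.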